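The source may hold more compounds than are shown below. What is called first, only, known or untested is meant among the compounds shown, and "the series" means these compounds.

Compound 1 `COc1cc(C(c2ccc(O)c(OC)c2)[C@@H](C)[C@H](C)CO)ccc1O`, > 100000 nM; compound 2 `CCCCC[C@H](C(C)C)C(c1ccc(O)c(OC)c1)c1ccc(O)c(OC)c1`, 9600 nM.

Among the compounds with values here, in a functional assay on HL-60 cells (Homo sapiens) for cytotoxicity, read by WST assay, with a stated time of 48 h (on this read-out lower numbers stand for stronger inhibition and higher numbers for weaker inhibition), compound 2 gives 9600 nM, the only plain number among the two measured compounds. Compound 1 reaches only a limit, > 100000 nM, which is the limit of > 100000 nM in this assay, at which 1 of the 2 values shown sits. Within the data shown here, the one measured step, an at least 10-fold lower number from compound 1 to compound 2 (1.01 log units; beyond the scatter), pairs the longer plain chain with the lower number. Compound 3 `COC[C@H](C(C)C)C(c1ccc(O)c(OC)c1)c1ccc(O)c(OC)c1` carries methoxy in place of butyl on a saturated chain carbon, three bonds along the chain from two aromatic carbons, moving back toward a shorter chain resembling compound 1. A higher number is therefore expected for compound 3, by roughly a 3.6-fold higher number from compound 2 to compound 3 (0.56 log units; beyond the scatter). The estimate for compound 3 is 35000 nM, within 10000 nM to 120000 nM, with a fair chance that only a limit results.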

Compound 3, half-maximal inhibitory concentration: 72000 nM
The estimate for compound 3 lay 2.1-fold (0.31 log units) below the measured number; the measured number falls inside the stated range.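

Within the data shown here, compound 1 and compound 2 differ across a whole side chain, whereas here only one place changes. Methoxy in place of butyl on a saturated chain carbon, three bonds along the chain from two aromatic carbons, gives a 7.5-fold higher number from compound 2 to compound 3 (0.88 log units; beyond the scatter). This change alone therefore moves the number beyond the scatter. All that can be said of the remaining step is an at least 1.3-fold lower number from compound 1 to compound 3 (0.14 log units; that floor lies within the scatter), and it cannot be read further, because one of its two values is only a limit: the limit of > 100000 nM in this assay, at which 1 of the 3 values shown sits.

Chain length and the oxygen change together in this step, so it remains open which of them goes with the higher number. An ethyl group or an amine at this place could tell them apart.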